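Ethoxycarbonyl in Place of Hydroxymethyl: Compound 2 to Compound 3

The source may hold more compounds than are shown below. What is called first, only, known or untested is meant among the compounds shown, and "the series" means these compounds.

Compound 2 `COc1cc([C@H]2C[C@@]2(CO)C(=O)Nc2ccccc2)cc(OC)c1OC` and compound 3 `CCOC(=O)[C@@]1(C(=O)Nc2ccccc2)C[C@@H]1c1cc(OC)c(OC)c(OC)c1` share one core, and compound 1 `CCOC(=O)C1(C(=O)Nc2ccccc2)CC1c1cc(OC)c(OC)c(OC)c1` carries the same groups as compound 3. In a functional assay on A549 cells (Homo sapiens) for cytotoxicity, read by MTT assay, with a stated time of 48 h (on this read-out higher numbers stand for weaker inhibition and lower numbers for stronger inhibition), compound 1 gives 31500 nM; 48600 nM (2 entries). In this assay compound 2 reaches only a limit of the assay, > 100000 nM, and not a number. Compound 3 differs from compound 2 by ethoxycarbonyl in place of hydroxymethyl on a saturated ring carbon. Going by the values given here, no step between measured compounds is recorded, yet the step of an at least 2.5-fold lower number from compound 2 to compound 3 (0.39 log units; beyond the scatter) is expected toward stronger inhibition because compound 1 gives 31500 nM; 48600 nM (2 entries). Compound 3 is expected to give 40000 nM, with a range from 12000 nM to 130000 nM.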

Compound 3, half-maximal inhibitory concentration: > 100000 nM
Compound 3: a limit, no number; the forecaster's own chance of this, stated with the estimate: 25%; at least 2.5-fold (0.39 log units) between middle value and limit.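

No step can be read between compound 2 and compound 3: in this assay each stands only at a limit of the assay, not at a number. The compounds shown leave open how large the effect of ethoxycarbonyl in place of hydroxymethyl on a saturated ring carbon is.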